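A Carboxy Group on the Ring of Compound 3

The source may hold more compounds than are shown below. What is called first, only, known or untested is meant among the compounds shown, and "the series" means these compounds.

In a functional assay on HL-60 cells (Homo sapiens) for inhibition, read by MTT assay, with a stated time of 48 h, tested at 10 uM (on this read-out higher numbers stand for more inhibition of growth at the one concentration tested and lower numbers for less inhibition of growth), compound 1 `Cc1cc(=O)c2c(O)cc(OCc3ccc(Br)cc3)c([C@H]3CCN(C)C[C@H]3O)c2o1` gives 27% and compound 2 `Cc1cc(=O)c2c(O)cc(OCc3ccc([N+](=O)[O-])cc3)c([C@H]3CCN(C)C[C@H]3O)c2o1` gives 14%, while compound 3 `Cc1cc(=O)c2c(O)c(CN3CCCC3)c(O)c([C@H]3CCN(C)C[C@H]3O)c2o1` stands highest of the three at 38% in this small set. Compound 4 `Cc1cc(=O)c2c(O)c(CN3CCCC3C(=O)O)c(O)c([C@H]3CCN(C)C[C@H]3O)c2o1` differs from compound 3 by carboxy in place of hydrogen on a saturated ring carbon. Among the measured compounds shown here, the only measured step (a number 13 percentage points lower from compound 1 to compound 2 (beyond the scatter)) lies elsewhere on the molecule and tests no such change, so it offers only a rough size. A modest fall is expected, since compound 3 at 38% holds the top number here. The expected change is a number 12 percentage points lower from compound 3 to compound 4 (beyond the scatter) as estimated. In this assay compound 4 is expected at 26% within an estimated range of 10% to 42% overall.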

Compound 4, percent growth inhibition at one concentration: 16%
The estimate for compound 4 lay 10 percentage points above the measured number; low and high end bracket the measured number.
By their numbers in this assay, from the lowest: compounds 2 and 4 (each within the scatter of the next); then compound 1; then compound 3.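

Carboxy in place of hydrogen on a saturated ring carbon, next to the ring nitrogen, gives a number 22 percentage points lower from compound 3 to compound 4 (beyond the scatter) in this assay. Among the compounds shown here, the earlier step lay elsewhere on the molecule, so this is the first sign that the number responds to a change on the five-membered ring. Nothing at hand accounts for this fall.

From the compounds shown here alone, whether the fall is specific to carboxy remains open, since a methyl ester, a primary amide or a hydroxymethyl group on the same carbon could be compared with it. Going by these compounds, whether a simple methyl group there would also lower the number is equally open.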